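Triazole substituent exchange on the chromene ester core

The source may hold more compounds than are shown below. What is called first, only, known or untested is meant among the compounds shown, and "the series" means these compounds.

Measured compounds:
- compound 1, `CCOC(=O)C1=Cc2ccccc2OC1(OCc1cn(-c2ccc(F)cc2)nn1)C(F)(F)F`: 9100 nM
- compound 2, `CCOC(=O)C1=Cc2ccccc2OC1(OCc1cc(-c2ccc(Br)cc2)no1)C(F)(F)F`: > 150000 nM
- compound 3, `O=C(O)C1=Cc2ccccc2OC1(OCc1cc(-c2ccc(F)cc2)no1)C(F)(F)F`: 64200 nM

Three compounds sharing the trifluoromethyl-bearing core have been run in a functional assay on MCF7 cells (Homo sapiens) for inhibition, read by MTT assay, with a stated time of 24 h; a lower number here means a stronger inhibitor, a higher number a weaker inhibitor. Compound 1 gives the lower of the two numerical values, 9100 nM. Compound 3, the free acid with the isoxazole arm, gives 64200 nM, a higher number and a gap beyond the scatter. Compound 2 is a limit rather than a number, sitting at the limit of > 150000 nM in this assay, at which 1 of the 3 values shown sits.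

The next compound, compound 4, `CCOC(=O)C1=Cc2ccccc2OC1(OCc1cn(CC(=O)Nc2ccc(I)cc2Cl)nn1)C(F)(F)F`, has not yet been measured in this assay. It is derived from compound 1 by the change (((2-chloro-4-iodophenyl)carbamoyl)methyl in place of 4-fluorophenyl on an aromatic nitrogen). For the measured compounds named here, because no pair of measured compounds differs in exactly one place, there is no measured step to lean on; the only guide is that the two numerical values and the one limit all lie in the weak range.

The expectation for compound 4 is therefore a small shift from compound 1, most likely toward a weaker number, giving a 1.6-fold higher number from compound 1 to compound 4 (0.22 log units; within the scatter). The estimate for compound 4 in this assay is 15000 nM, with a range from 3000 nM to 80000 nM.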

Compound 4, half-maximal inhibitory concentration: 28100 nM
Estimate against measurement, compound 4: 1.9-fold (0.27 log units) below, within the range that was stated.
By their numbers in this assay, from the lowest: compound 1; then compound 4; then compound 3. At a limit, above all of these: compound 2.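

In this assay, for the compounds shown here, the exchange on the aromatic nitrogen gives the first one-place comparison: ((2-chloro-4-iodophenyl)carbamoyl)methyl in place of 4-fluorophenyl produces a 3.1-fold higher number from compound 1 to compound 4 (0.49 log units; beyond the scatter) and so shows that this position affects the read-out. The effect is modest for a substantial change: the entering group is larger and adds an amide between the nitrogen substituent's methyl carbon and its aromatic ring, yet compound 4 still gives a numerical value, 28100 nM, and not a limit. Going by these compounds alone, the single step shows the size of the shift but not its cause, and nothing measured in this set bears on why the number rises.

From the compounds shown here alone, the step changes the carbamoyl methyl link, the chlorine, the iodine and the loss of fluorine together, so the share of each in the shift stays open. Going by these compounds, it also remains open whether a plain benzyl group or an unsubstituted phenylacetamide on the same nitrogen would stay close to compound 1 or move the number further, and whether the direction of this step holds on other members.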